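The source may report more compounds than this note shows. Statements on the series, on what has been measured and on what is new or still open speak of the compounds shown alone.

Measured compounds:
- Compound 1, `CCc1cnc(N2CCC(n3ncc4cc(-c5ccc(S(C)(=O)=O)cc5)ncc43)CC2)nc1`: 260 nM
- Compound 2, `CCc1cnc(N2CCC(n3ncc4cc(-c5ccc(S(C)(=O)=O)cc5)ccc43)CC2)nc1`: < 110 nM
- Compound 3, `CCc1cnc(N2CCC(n3nnc4cc(-c5ccc(S(C)(=O)=O)cc5)ncc43)CC2)nc1`: 280 nM

These three compounds were tested in a physicochemical assay for solubility, read by HPLC, in phosphate buffer, measured as thermodynamic solubility, with a stated time of 24 h, at pH 6.8; on this read-out lower numbers stand for lower solubility and higher numbers for higher solubility. Compound 1 gives 260 nM in this assay. For compound 2 the result is a limit of the assay rather than a number, < 110 nM, and so the limit of < 110 nM in this assay, at which 1 of the 3 values shown sits, is the only thing known of it. Compound 3 gives 280 nM, which is the highest of the two numbers available; its nearest neighbour is compound 1, and the two values lie within the usual scatter of each other, so no order can be read between them.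

Compound 4, `CCc1cnc(N2CCC(n3nnc4cc(-c5ccc(S(C)(=O)=O)cc5F)ncc43)CC2)nc1`, has not yet been measured in this assay. It is derived from compound 3 by a single change: fluoro in place of hydrogen on an aromatic carbon. Within the data shown here, no pair of measured compounds differs in just this way, so there is no measured step to lean on. The expected step from compound 3 to compound 4 is a 1.3-fold lower number from compound 3 to compound 4 (0.10 log units; within the scatter), a small change that would stay within the scatter. Compound 4 is therefore estimated at 220 nM, with a range from 100 nM to 480 nM.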

Compound 4, solubility: < 120 nM
Compound 4: a limit, no number; the forecaster's own chance of this, stated with the estimate: 20%; middle value at least 1.8-fold (0.26 log units) from the limit.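

In this assay, fluoro in place of hydrogen on an aromatic carbon, ortho to a large group and meta to a methylsulfonyl group, comes with an at least 2.3-fold lower number from compound 3 to compound 4 (0.36 log units; beyond the scatter). This is the first step shown on this ring, since the earlier compounds all carry the same unchanged 4-(methylsulfonyl)phenyl group and differ only in the core. The result for compound 4 is a limit of the assay and not a number, so the step has a known minimum but no known full size: the limit of < 120 nM in this assay, at which 1 of the 4 values shown sits.

The compounds shown leave open how far compound 4 really lies from compound 3, and whether another group on this same carbon, such as a methoxy group or an amine, would read differently from fluoro. They also leave open whether fluoro at this place would give a similar step on the core of compound 1.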